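Swapping a Dichlorophenyl Ring for a Small Thiophene

The source may report more compounds than this note shows. Statements on the series, on what has been measured and on what is new or still open speak of the compounds shown alone.

Compound 1, `COc1cc(C(=O)c2sc(-c3ccc(C)cc3)cc2N)cc(OC)c1OC`: 15 nM
Compound 2, `COc1cc(C(=O)c2sc(-c3ccc(Cl)cc3)cc2N)cc(OC)c1OC`: 70 nM
Compound 3, `COc1cc(C(=O)c2sc(-c3ccc(Cl)c(Cl)c3)cc2N)cc(OC)c1OC`: 290 nM

Of the compounds shown here, three sharing one core have been tested in a functional assay on CCRF-CEM cells (Homo sapiens) for antiproliferative activity; on this read-out higher numbers stand for weaker inhibition and lower numbers for stronger inhibition. Compound 3 gives the highest number of the three, and both gaps separating it from the others lie beyond the scatter: compound 2 sits closest, and compound 1 is furthest away, with a 19-fold higher number from compound 1 to compound 3 (1.29 log units; beyond the scatter).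

The two steps leading to compound 3 point the same way. Going from compound 1 to compound 2 there was a 4.7-fold higher number from compound 1 to compound 2 (0.67 log units; beyond the scatter), and from compound 2 to compound 3 there was a 4.1-fold higher number from compound 2 to compound 3 (0.62 log units; beyond the scatter). In both cases a chlorine entered the pendant aromatic ring and the number rose.

Compound 4, `COc1cc(C(=O)c2sc(-c3ccsc3)cc2N)cc(OC)c1OC`, is not yet measured. Its change from compound 3 is thiophen-3-yl in place of 3,4-dichlorophenyl on an aromatic carbon. For the measured compounds named here, both chlorines leave and a smaller ring enters, so none of the measured steps describes this exact change; they only show that each added chlorine weakened inhibition by a modest amount. From the compounds shown here alone, removing both is therefore expected to lower the number, estimated as a 4.8-fold lower number from compound 3 to compound 4 (0.68 log units; beyond the scatter), though how the new ring itself behaves is unknown. Compound 4 is expected to give about 60 nM in this assay, within a range from 15 nM to 250 nM.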

Compound 4, half-maximal inhibitory concentration: 9.6 nM
Beside the measured number, compound 4's estimate is 6.3-fold (0.80 log units) above it; measured number outside the range, below it.
By their numbers in this assay, from the lowest: compounds 4 and 1 (each within the scatter of the next); then compound 2; then compound 3.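

In this assay, the carbon next to the ring sulfur turns out to hold more than a substituted six-membered ring: thiophen-3-yl, a five-membered aromatic ring with one sulfur, gives a 30-fold lower number from compound 3 to compound 4 (1.48 log units; beyond the scatter) and, against the 4-chlorophenyl group, a 7.3-fold lower number from compound 2 to compound 4 (0.86 log units; beyond the scatter) as well. The comparison with the 4-methylphenyl group gives a 1.6-fold lower number from compound 1 to compound 4 (0.19 log units; within the scatter), so thiophen-3-yl and 4-methylphenyl cannot be told apart at this position in this read-out. The earlier compounds varied only the substituents on a phenyl ring, whereas this change replaces the ring itself and shows that a six-membered carbon ring is not needed for a low number, though no measurement here explains why the swap has this effect.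

What remains open is whether the ring size, the sulfur or simply the absence of chlorine matters most, since unsubstituted phenyl, thiophen-2-yl and furan-3-yl are not among the compounds shown. It is also unclear whether a thiophen-3-yl ring carrying a methyl group or a chlorine would follow the trend seen on the phenyl ring.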